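This account rests on a few compounds, and the source may have more. Where it says the series, first, only, none or still open, it means among the compounds named here.

Measured in a functional assay on SW480 cells (Homo sapiens) for antiproliferative activity, read by sulforhodamine B assay, with a stated time of 48 h; a higher number here means a weaker inhibitor, a lower number a stronger inhibitor:
compound 1 `COc1ccc(/C=C/C(=O)c2ccccc2-c2ccc(F)cc2)cc1OC` gives 570 nM
compound 2 `COc1cc(/C=C/C(=O)c2ccccc2-c2ccc(F)cc2)ccc1O` gives 6600 nM

Compound 1 holds the lower number of the two, making it the stronger inhibitor. Compound 3 `COc1ccc(/C=C/C(=O)c2ccccc2-c2ccc(F)cc2)cc1B(O)O` is unmeasured and differs from it thus: a group of 3 heavy atoms (1 boron, 2 oxygen; no ring) in place of a group of 2 heavy atoms (1 carbon, 1 oxygen; no ring), on an aromatic carbon. The change lies on an aromatic carbon, ortho to a methoxy group and meta to a large group. Going by the values given here, only one measured step bears on it, and only loosely: a 12-fold higher number from compound 1 to compound 2 (1.06 log units; beyond the scatter), which alters the other methoxy group. A smaller rise is therefore expected in this assay, estimated as a 2.6-fold higher number from compound 1 to compound 3 (0.42 log units; beyond the scatter) in size. Compound 3 is expected at 1500 nM (range 200 nM to 9000 nM).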

Compound 3, half-maximal inhibitory concentration: 41 nM
Compound 3: the middle estimate sits 37-fold (1.56 log units) above what was measured, outside the stated range (below it).
By their numbers in this assay, from the lowest: compound 3; then compound 1; then compound 2.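

In this assay, replacing the methoxy group ortho to the other methoxy group with a group of 3 heavy atoms (1 boron, 2 oxygen) gives a 14-fold lower number from compound 1 to compound 3 (1.14 log units; beyond the scatter). The earlier change, at the other methoxy group, went the opposite way, with a 12-fold higher number from compound 1 to compound 2 (1.06 log units; beyond the scatter), so this position tolerates substitution and the two sites do not respond alike. No measurement given here accounts for the gain. The compounds shown leave open whether a carboxylic acid or an amine on this aromatic carbon would lower the number too, or whether boron is needed.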